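Enlarging the amine on the side chain of compound 3

The compounds below may be only part of what the source reports. "The series", "measured", "known", "first", "only" and "open" are said of these compounds alone.

In a functional assay on MCF7 cells (Homo sapiens) for antiproliferative activity (a lower number here means a stronger inhibitor, a higher number a weaker inhibitor), compound 1 `CC(=O)Oc1ccc(C(=O)Nc2cc3ccc(OCC4CCN(C)C4)c(C)c3oc2=O)cc1CC=C(C)C` gives 1880 nM and compound 2 `CC(C)=CCc1cc(C(=O)Nc2cc3ccc(OCC4CCCN(C)C4)c(C)c3oc2=O)ccc1O` gives 2640 nM while compound 3 `CCNCCCOc1ccc2cc(NC(=O)c3ccc(O)c(CC=C(C)C)c3)c(=O)oc2c1C` gives 980 nM as its value. Compound 3 thus stands beyond the scatter of compound 2 but within the scatter of compound 1, so those two cannot be ranked. Compound 4 `CCCN(CCC)CCCOc1ccc2cc(NC(=O)c3ccc(O)c(CC=C(C)C)c3)c(=O)oc2c1C` carries dipropylamino in place of ethylamino on a saturated chain carbon, three bonds along the chain from an oxygen on an aromatic ring, and the difference counts as dipropylamino in place of ethylamino on a saturated chain carbon, three bonds along the chain from an oxygen on an aromatic ring in all. Within the data shown here, the only measured step that alters this amine side chain is a 2.7-fold lower number from compound 2 to compound 3 (0.43 log units; beyond the scatter) and it is modest. Among the measured compounds shown here, no measured compound carries dipropylamino, so that step guides only the size expected. A step no larger is expected in this assay with a slight, weakly supported lean toward a higher number, possibly none beyond the scatter. The expected change is a 1.4-fold higher number from compound 3 to compound 4 (0.15 log units; within the scatter) by this estimate. For compound 4 the estimated value is 1400 nM with an expected range of 500 nM to 3600 nM around it.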

Compound 4, half-maximal inhibitory concentration: > 50000 nM
Compound 4: no number, only a limit (the forecaster's own chance of this, stated with the estimate: 3%); middle value at least 35-fold (1.55 log units) from the limit.
By their numbers in this assay, from the lowest: compounds 3, 1 and 2 (each within the scatter of the next, the first and the last beyond it). At a limit, above all of these: compound 4.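

For compound 4, the reading in this assay is a limit of the assay and not a number: the limit of > 50000 nM in this assay, at which 1 of the 4 values shown sits.

Even so, the amine on this saturated chain carbon proves far less forgiving than the earlier compounds suggested, as dipropylamino in place of ethylamino gives an at least 51-fold higher number from compound 3 to compound 4 (1.70 log units; beyond the scatter), a large step where the only earlier change to this side chain gave a 2.7-fold lower number from compound 2 to compound 3 (0.43 log units; beyond the scatter). The side chain of compound 4 also compares poorly with the 1-methylpiperidin-3-yl side chain, with an at least 18-fold higher number from compound 2 to compound 4 (1.27 log units; beyond the scatter).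

The change adds heavy atoms and also removes the hydrogen-bond donor, and the compounds shown cannot separate these two differences. Propylamino and diethylamino on the same chain would be needed to tell them apart, and neither stands among the compounds shown.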